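The source may hold more compounds than are shown below. What is called first, only, known or untested is meant among the compounds shown, and "the series" means these compounds.

Compound 1 `C[C@@H](Cn1ccc(-c2ccc(C#N)c(Cl)c2)n1)NC(=O)c1ccccc1` is the weaker of the two measured compounds: in a functional assay on LNCaP cells (Homo sapiens) for antiproliferative activity, read by CCK-8 assay, with a stated time of 6 days (on this read-out higher numbers stand for weaker inhibition and lower numbers for stronger inhibition), compound 1 gives 1830 nM, the highest of the two numbers shown. Its nearest neighbour, compound 2 `C[C@@H](Cn1ccc(-c2ccc(C#N)c(Cl)c2)n1)NC(=O)c1cccc(OCC(O)CO)c1`, gives 740 nM in this assay; that step, a 2.5-fold lower number from compound 1 to compound 2 (0.39 log units; beyond the scatter), comes from placing 2,3-dihydroxypropoxy in place of hydrogen on an aromatic carbon, leaving the amide untouched.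

Compound 3 `C[C@@H](Cn1ccc(-c2ccc(C#N)c(Cl)c2)n1)NS(=O)(=O)c1cn(C)cn1` changes a different part of compound 1: (1-methyl-1H-imidazol-4-yl)sulfonyl in place of benzoyl on an amine nitrogen. Within the data shown here, no measured step touches this amine nitrogen, so the only comparison available, the step to compound 2, concerns another site and gives no direction for this change. With nothing to lean on, the expected step of a 1.4-fold higher number from compound 1 to compound 3 (0.14 log units; within the scatter) is small, with a wide range in both directions. Compound 3 is therefore estimated at 2500 nM in this assay, within 700 nM to 9000 nM.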

Compound 3, half-maximal inhibitory concentration: > 30000 nM
Compound 3: no number, only a limit (the forecaster's own chance of this, stated with the estimate: 15%); middle value at least 12-fold (1.07 log units) from the limit.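

Placing (1-methyl-1H-imidazol-4-yl)sulfonyl in place of benzoyl on the amine nitrogen gives, in this assay, an at least 16-fold higher number from compound 1 to compound 3 (1.21 log units; beyond the scatter). For compound 3 the result is a limit and not a number: the limit of > 30000 nM in this assay, at which 1 of the 3 values shown sits. Among these compounds, the only earlier step, a 2.5-fold lower number from compound 1 to compound 2 (0.39 log units; beyond the scatter), was modest and concerned an aromatic carbon of the benzoyl group, so this is the first sign that the group on this amine nitrogen can matter much more.

Benzoyl left as a whole, and the sulfonyl link and the five-membered aromatic ring entered together. The compounds shown cannot separate what each contributes. A benzenesulfonyl group or a 1-methyl-1H-imidazole-4-carbonyl group on this amine nitrogen would change only one of the two and could tell them apart.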